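Compound 3: nitro in place of tert-butyl

The compounds below may be only part of what the source reports. "The series", "measured", "known", "first", "only" and "open" are said of these compounds alone.

Going by the values given here, in a functional assay on MCF7 cells (Homo sapiens) for antiproliferative activity, read by MTT assay, with a stated time of 72 h (on this read-out higher numbers stand for weaker inhibition and lower numbers for stronger inhibition), compound 1 `COc1ccc(/C=C2/CN(C)/C(=N/c3ccc(C(C)(C)C)cc3)S2)cc1` gives 28700 nM, the only actual number so far. Compound 2 `C=CC/N=C1/NCC(=C)S1` reads > 100000 nM in this assay. That reading is a limit of the assay and not a number. Compound 1 therefore provides the single numeric reference point.

The next compound to be read is compound 3 `COc1ccc(/C=C2/CN(C)/C(=N/c3ccc([N+](=O)[O-])cc3)S2)cc1`. It keeps the rest of compound 1 and carries nitro in place of tert-butyl on an aromatic carbon, para to a large group (nitro in place of tert-butyl on an aromatic carbon).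

Among the compounds with values here, no measured pair isolates this exchange, so the expectation is weakly grounded. Compound 3 shares everything else with compound 1, which gives 28700 nM, and the expectation starts from that value. A modest shift towards stronger inhibition in this assay is expected, though a result within the scatter would be unsurprising. The expected step of a 1.4-fold lower number from compound 1 to compound 3 (0.16 log units; within the scatter) is small. For compound 3 the estimated value is 20000 nM, with an expected range of 7000 nM to 60000 nM.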

Compound 3, half-maximal inhibitory concentration: 9800 nM
For compound 3 the middle estimate is 2.0-fold (0.31 log units) above the measured one; measured number inside the range.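

In this assay, going by these compounds alone, nitro in place of tert-butyl on an aromatic carbon, para to a large group, gives a 2.9-fold lower number from compound 1 to compound 3 (0.47 log units; beyond the scatter) and is the first step that can be read as a number. With the rest of the core of compound 1 held constant, the read-out at this position therefore responds to the identity of the substituent, and a group of carbon only can give way to one carrying nitrogen and oxygen without loss of inhibition on these cells. The data in hand give no measured property that accounts for the size of this step, so it stands as an observation on a single pair.

A single pair cannot separate what the arrival of nitro contributes from what the departure of tert-butyl contributes, and an amine, a carboxylic acid or a chlorine atom at the same position would show how far the read-out moves with other groups. Within the data shown here, compound 2 reads > 100000 nM, which is a limit of the assay and not a number, and it differs from the other compounds in more than one place, so it adds no step.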